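A Second Carboxy Group on the Amide Nitrogen

A few compounds are considered here, and "the series" means these few. Any claim that something is new, unique, unknown or untested is made for them only; others in the source may bear on it.

In a functional assay on PC-3 cells (Homo sapiens) for antiproliferative activity, read by MTT assay, with a stated time of 24 h (a higher number here means a weaker inhibitor, a lower number a stronger inhibitor), compound 1 `CCn1c(C(=O)N[C@H](C)CO)ccc1C(CC)(CC)c1ccc(OCS(=O)(=O)c2ccccc2)c(C)c1` gives 7790 nM while compound 2 `CCn1c(C(=O)N[C@@H](CO)CCCO)ccc1C(CC)(CC)c1ccc(OCS(=O)(=O)c2ccccc2)c(C)c1` gives 13400 nM and compound 3 `CCn1c(C(=O)N[C@H](C(=O)O)C(C)C)ccc1C(CC)(CC)c1ccc(OCS(=O)(=O)c2ccccc2)c(C)c1` gives 3650 nM as the lowest of the three numbers. Compound 4 `CCn1c(C(=O)N[C@H](CCC(=O)O)C(=O)O)ccc1C(CC)(CC)c1ccc(OCS(=O)(=O)c2ccccc2)c(C)c1` is still unmeasured and carries 1,3-dicarboxypropyl in place of 1-carboxy-2-methylpropyl on an amide-type nitrogen. Within the data shown here, no measured step makes this exact change. Among the measured compounds shown here, the nearest evidence is two modest steps into the one carboxy-bearing compound measured so far, namely a 2.1-fold lower number from compound 1 to compound 3 (0.33 log units; beyond the scatter) and a 3.7-fold lower number from compound 2 to compound 3 (0.56 log units; beyond the scatter) on that same nitrogen. Adding 2-hydroxyethyl gave a 1.7-fold higher number from compound 1 to compound 2 (0.24 log units; within the scatter) and so stayed within the scatter. Nothing measured shows what a second carboxy group does. A step no larger than those modest ones is therefore expected in this assay and its direction is uncertain, with a slightly higher number favoured. The step expected is a 1.4-fold higher number from compound 3 to compound 4 (0.14 log units; within the scatter) on this estimate. The estimate for compound 4 is 5000 nM within an expected range of 1800 nM to 14000 nM for repeat measurements.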

Compound 4, half-maximal inhibitory concentration: > 50000 nM
Compound 4 ended at the assay's limit; the forecaster's own chance of this, stated with the estimate: 10%; middle value at least 10-fold (1.00 log units) away from the limit.
By their numbers in this assay, from the lowest: compound 3; then compounds 1 and 2 (each within the scatter of the next). At a limit, above all of these: compound 4.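

Compound 4 is the only one of the four compounds to sit at a limit of this assay, and this is a limit, not a number: the limit of > 50000 nM in this assay, at which 1 of the 4 values shown sits.

Placing 1,3-dicarboxypropyl instead of 1-carboxy-2-methylpropyl on the amide-type nitrogen gives an at least 13-fold higher number from compound 3 to compound 4 (1.13 log units; beyond the scatter), so a carboxy-bearing group on this nitrogen does not by itself go with the lowest number. The two compounds with hydroxy-bearing groups on that nitrogen also differ from this one, with an at least 3.7-fold higher number from compound 2 to compound 4 (0.57 log units; beyond the scatter) and an at least 6.4-fold higher number from compound 1 to compound 4 (0.80 log units; beyond the scatter).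

The compounds shown leave open whether the second carboxylic acid or the chain that carries it matters more. An amine or a primary amide at the end of that chain, or a shorter chain bearing the same carboxylic acid, would separate the two.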